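The source may hold more compounds than are shown below. What is called first, only, known or untested is meant among the compounds shown, and "the series" means these compounds.

Values in a functional assay on PC-3 cells (Homo sapiens) for inhibition, read by sulforhodamine B assay, with a stated time of 72 h; on this read-out higher numbers stand for weaker inhibition and lower numbers for stronger inhibition:
- compound 1 `Nc1sc(-c2ccc(Cl)cc2)c(-c2ccc(Cl)cc2)c1C(=O)N1CCCCC1`: 14300 nM
- compound 2 `Nc1sc(-c2ccc(Cl)cc2)c(-c2ccc(Cl)cc2)c1C(=O)N1CCCCC1=O`: 4940 nM
- compound 3 `CC(C)(C)NC(=O)c1c(N)sc(-c2ccc(Cl)cc2)c1-c1ccc(Cl)cc1`: 15100 nM

Compound 3 stands at the upper end of these numbers, but it does not stand there alone. Its gaps to the other two read a 1.1-fold higher number from compound 1 to compound 3 (0.02 log units; within the scatter) and a 3.1-fold higher number from compound 2 to compound 3 (0.49 log units; beyond the scatter).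

Next is compound 4 `COc1ccc(CNC(=O)c2c(N)sc(-c3ccc(Cl)cc3)c2-c2ccc(Cl)cc2)cc1`, with 4-methoxybenzyl in place of tert-butyl on an amide-type nitrogen. Going by the values given here, no measured compound carries 4-methoxybenzyl, so this step has no direct precedent. Among the compounds with values here, the only guide is the set of three changes at the same carbonyl carbon, all on an unchanged core. The largest of these is modest, a 3.1-fold higher number from compound 2 to compound 3 (0.49 log units; beyond the scatter), and a 2.9-fold lower number from compound 1 to compound 2 (0.46 log units; beyond the scatter) is of similar size. The swap closest to the coming one, which introduces the (tert-butyl)amino group, gave a 1.1-fold higher number from compound 1 to compound 3 (0.02 log units; within the scatter).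

On that evidence, a large move in this assay is not expected. The expected result is no step beyond the scatter, with a slight lean toward a lower number: a 1.5-fold lower number from compound 3 to compound 4 (0.18 log units; within the scatter). Compound 4 is estimated at 10000 nM, with an expected range of 3500 nM to 30000 nM.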

Compound 4, half-maximal inhibitory concentration: 29500 nM
The estimate for compound 4 lay 3.0-fold (0.47 log units) below the measured number; the range from low to high includes it.
By their numbers in this assay, from the lowest: compound 2; then compounds 1, 3 and 4 (each within the scatter of the next, the first and the last beyond it).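

In this assay, the amide-type nitrogen accepts 4-methoxybenzyl in place of tert-butyl, bringing in a six-membered aromatic ring and a hydrogen-bond acceptor, with a step that stays within the scatter: a 2.0-fold higher number from compound 3 to compound 4 (0.29 log units; within the scatter). Against the other two groups on the carbonyl carbon, (4-methoxybenzyl)amino gives a 2.1-fold higher number from compound 1 to compound 4 (0.31 log units; beyond the scatter) and a 6.0-fold higher number from compound 2 to compound 4 (0.78 log units; beyond the scatter), the latter being the largest step so far, though still modest, and compound 2 remains the only compound set apart from all the others at the low end. No measurement in hand accounts for these differences.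

Still open, going by these compounds, is how unsubstituted benzyl or 2-phenylethyl on the amide-type nitrogen would read, and therefore whether the methoxy group or the benzyl part has any bearing on the number. Also open, on these data alone, is whether the lower number of compound 2 extends to other groups on the carbonyl carbon, such as 2-oxopyrrolidin-1-yl or morpholin-4-yl, or stays confined to 2-oxopiperidin-1-yl.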